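The compounds below may be only part of what the source reports. "The series", "measured", "known", "first", "only" and "open" are said of these compounds alone.

Going by the values given here, compound 3 `Cc1cccc(NC(=O)CN2CCN(c3ncccn3)CC2)c1` is the only compound with a number in an assay on cells for agonist activity at D(4) dopamine receptor (Homo sapiens), read by luminescence and beta-arrestin recruitment, with a stated time of 90 min; on this read-out lower numbers stand for an effect already at smaller amounts and higher numbers for an effect only at larger amounts of compound: compound 3 gives 278 nM. Two further entries carry no number at all. Compound 1 `Cc1cccc(NC(=O)CN2CCC(c3ccc(Cl)cc3)CC2)c1` is reported in this assay as "not active" (no number reported), and compound 2 `Cc1ccc(C2CCN(CC(=O)Nc3cccc(C)c3)CC2)nc1` is reported in this assay as "not active" (no number reported). Compound 4 `Cc1cccc(NC(=O)CN2CCN(c3ccc(Cl)cn3)CC2)c1` differs from compound 3 in one place: 5-chloropyridin-2-yl in place of pyrimidin-2-yl on an amine nitrogen in a ring. Among the compounds with values here, no step between measured compounds shows how such a change plays out, so the expectation rests on compound 3 alone. The step of a 1.4-fold lower number from compound 3 to compound 4 (0.14 log units; within the scatter) is estimated to be small, not beyond the usual scatter, with at most a slight lean toward lower numbers. Compound 4 is therefore expected to give about 200 nM in this assay, within a range from 50 nM to 800 nM.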

Compound 4, half-maximal effective concentration: "not active" (no number reported)
Compound 4: no number reported; no gap can be computed for the estimate.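

Going by these compounds alone, compound 4 has no number, and no step from compound 3 to compound 4 can be read. No measurement shown bears on this result. The compounds shown leave open whether any group other than pyrimidin-2-yl on the amine nitrogen gives a number in this assay.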